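The source may report more compounds than this note shows. Statements on the series, on what has been measured and on what is new or still open speak of the compounds shown alone.

Among the measured compounds shown here, in a functional assay on HL-60 cells (Homo sapiens) for antiproliferative activity, read by XTT assay, with a stated time of 72 h (a lower number here means a stronger inhibitor, a higher number a weaker inhibitor), only two compounds sharing one core have been measured so far. Compound 1 `Cc1ncnc2c1c(-c1ccoc1)cn2[C@@H]1O[C@H](CO)[C@@H](O)[C@H]1O`, which carries furan-3-yl, reads > 15000 nM, and this is a limit of the assay and not a number. For the measured compounds named here, compound 2 `C#Cc1cn([C@@H]2O[C@H](CO)[C@@H](O)[C@H]2O)c2ncnc(C)c12`, with ethynyl on the same aromatic carbon, gives 1110 nM, the only true number available. Going by the values given here, the single measured step, an at least 13-fold lower number from compound 1 to compound 2 (1.13 log units; beyond the scatter), is large, and it is the only guide to changes at this carbon.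

Compound 3 `Cc1ncnc2c1c(I)cn2[C@@H]1O[C@H](CO)[C@@H](O)[C@H]1O` alters that carbon again: iodo in place of ethynyl on an aromatic carbon. Iodo, like ethynyl, brings no ring, so the step of an at least 13-fold lower number from compound 1 to compound 2 (1.13 log units; beyond the scatter) gives no reason to expect a fall back to the limit seen for compound 1. The expected change is small, a 1.8-fold higher number from compound 2 to compound 3 (0.26 log units; within the scatter), a slight rise within the scatter in this assay. For compound 3 the estimate is 2000 nM, with an expected range of 400 nM to 10000 nM.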

Compound 3, half-maximal inhibitory concentration: 2650 nM
Compound 3: the middle estimate sits 1.3-fold (0.12 log units) below what was measured; measured number inside the range.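

Replacing ethynyl with iodo, two groups that bring no ring, still gives a 2.4-fold higher number from compound 2 to compound 3 (0.38 log units; beyond the scatter) in this assay, so these two groups are not interchangeable at this carbon. Iodo in place of furan-3-yl gives an at least 5.6-fold lower number from compound 1 to compound 3 (0.75 log units; beyond the scatter), so a second group without a ring also reads lower than the furan-3-yl compound. The true size of that step stays unknown, as compound 1 reads at a limit of the assay and not at a number: the limit of > 15000 nM in this assay, at which 1 of the 3 values shown sits.

On these data alone, the contrast between ring and no ring rests on furan-3-yl alone, so it remains open whether a phenyl ring or another ring at this carbon would read like compound 1. As far as these compounds go, it also remains open how groups such as an amine, a nitrile or a longer chain would read at this carbon.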